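The source may hold more compounds than are shown below. What is called first, only, known or untested is meant among the compounds shown, and "the series" means these compounds.

Compound 1 `O=c1ccn([C@@H]2O[C@H](COP(=O)(O)OP(=O)(O)OP(=O)(O)O)[C@@H](O)[C@H]2O)c(=S)[nH]1`: 1770 nM
Compound 2 `Cn1c(=O)ccn([C@@H]2O[C@H](COP(=O)(O)OP(=O)(O)OP(=O)(O)O)[C@@H](O)[C@H]2O)c1=O`: 2920 nM
Compound 3 `O=c1[nH]c(=O)n([C@@H]2O[C@H](COP(=O)(O)OP(=O)(O)OP(=O)(O)O)[C@@H](O)[C@H]2O)cc1Br`: 3460 nM

Of the compounds shown here, three have been measured in an in vitro functional assay on 1321-N1 cells for agonist activity at P2Y purinoceptor 4 (Homo sapiens); on this read-out higher numbers stand for an effect only at larger amounts of compound and lower numbers for an effect already at smaller amounts. Compound 1 gives 1770 nM, compound 2 gives 2920 nM, and compound 3 gives 3460 nM. Compound 2 stands second highest of the three numbers, nearest to compound 3 (a 1.2-fold higher number from compound 2 to compound 3 (0.07 log units; within the scatter)) and furthest from compound 1 (a 1.6-fold higher number from compound 1 to compound 2 (0.22 log units; within the scatter)); the remaining step, a 2.0-fold higher number from compound 1 to compound 3 (0.29 log units; within the scatter), is likewise within the scatter. All three measured steps swap the group on a saturated ring carbon and leave the rest of the molecule untouched.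

Compound 4 `Cn1c(=O)ccn([C@@H]2O[C@H](COP(=O)(O)O)[C@@H](O)[C@H]2O)c1=O` differs from compound 2 in another place: a hydrogen atom in place of a group of 8 heavy atoms (6 oxygen, 2 phosphorus; no ring), on an oxygen. Within the data shown here, none of the measured steps bears on this change, so they give no direct guide; they only show that the shared core tolerates the variations tried so far without a step beyond the scatter. The group that leaves is a large part of the molecule, and removing it is expected to raise the number sharply, with a real chance that this assay reports only a limit. Compound 4 is therefore estimated at 40000 nM in this assay, within a range from 5000 nM to 300000 nM, which means an expected step of a 14-fold higher number from compound 2 to compound 4 (1.14 log units; beyond the scatter).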

Compound 4, half-maximal effective concentration: > 100000 nM
Compound 4 was reported as a limit; the forecaster's own chance of this, stated with the estimate: 60%; at least 2.5-fold (0.39 log units) between middle value and limit.
By their numbers in this assay, from the lowest: compounds 1, 2 and 3 (each within the scatter of the next). At a limit, above all of these: compound 4.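

Compound 4 is reported only as a limit: the limit of > 100000 nM in this assay, at which 1 of the 4 values shown sits. Even so, an at least 34-fold higher number from compound 2 to compound 4 (1.53 log units; beyond the scatter) is the first step shown that lies beyond the scatter, whereas the swaps of the group on the saturated ring carbon among compound 1, compound 2 and compound 3 all stay within it. In this pair, the change on an oxygen whose other neighbours are phosphorus matters far more in this assay than any of those swaps, although this rests on a single pair of compounds.

The compounds shown leave open what a diphosphate on that oxygen would give, since only the full group and the hydrogen atom in its place appear here. They also leave open whether a carboxylic acid or a phosphonate there could stand in for the group that leaves.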